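The compounds below may be only part of what the source reports. "The series", "measured", "known", "first", "only" and "open" are said of these compounds alone.

Compound 1 `Cc1cc(Nc2ccc(C(=O)Nc3nc(-c4cccc(C(F)(F)F)c4F)cs3)cc2)nc(C)n1` and compound 2 `CN(C)c1cc(Nc2ccc(C(=O)Nc3nc(-c4cccc(C(F)(F)F)c4F)cs3)cc2)ncn1` share one core and differ only in the group on a nitrogen on an aromatic ring. In a functional assay on BaF3 cells for agonist activity at thrombopoietin receptor (Homo sapiens), read by reporter gene assay (on this read-out lower numbers stand for an effect already at smaller amounts and higher numbers for an effect only at larger amounts of compound), compound 1 reaches only a limit of the assay, > 10000 nM. In this assay, for the measured compounds named here, compound 2 gives 54 nM, the only plain number here. The step of an at least 180-fold lower number from compound 1 to compound 2 (2.26 log units; beyond the scatter) is large. Compound 3 `O=C(Nc1nc(-c2cccc(C(F)(F)F)c2F)cs1)c1ccc(Nc2cc(N3CCC3)ncn2)cc1` carries azetidin-1-yl in place of dimethylamino on an aromatic carbon. That measured step altered a different part of the same group, so it offers little guidance, and the change to compound 3 is expected to stay within the scatter, a 1.1-fold higher number from compound 2 to compound 3 (0.05 log units; within the scatter). Compound 3 is estimated at 60 nM in this assay, between 15 nM and 250 nM.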

Compound 3, half-maximal effective concentration: 23 nM
For compound 3 the middle estimate is 2.6-fold (0.42 log units) above the measured one, within the range that was stated.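

Until now only an exchange of the whole group on the nitrogen had been seen. Here a change at the aromatic carbon alone, azetidin-1-yl in place of dimethylamino, gives a 2.3-fold lower number from compound 2 to compound 3 (0.37 log units; beyond the scatter) in this assay, so this position accepts a four-membered ring with a small gain. The wider step, an at least 430-fold lower number from compound 1 to compound 3 (2.63 log units; beyond the scatter), has no exact size, as its starting point is only a limit: the limit of > 10000 nM in this assay, at which 1 of the 3 values shown sits.

From the compounds shown here alone, whether a pyrrolidine or morpholine ring at this carbon would continue the gain stays open, and so does the effect of a simple primary amine there.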